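A few compounds are considered here, and "the series" means these few. Any claim that something is new, unique, unknown or untested is made for them only; others in the source may bear on it.

Compound 1 `CC1CCCN(c2c(C#N)c(C(F)(F)F)nn2-c2ccc(S(C)(=O)=O)cc2)C1` offers no number to start from: in a physicochemical assay for solubility (on this read-out lower numbers stand for lower solubility and higher numbers for higher solubility), compound 1 stands as "not determined" (no result reported). Its relative compound 2 `CC1CCCN(c2c(C#N)c(C(F)F)nn2-c2ccc(S(C)(=O)=O)cc2)C1` gives 50 ug/mL. Compound 3 `CC(C)COc1c(C#N)c(C(F)(F)F)nn1-c1ccc(S(C)(=O)=O)cn1` returns only a limit, < 25 ug/mL. Compound 4 `CCC(C)Oc1c(C#N)c(C(F)(F)F)nn1-c1ccc(S(C)(=O)=O)cc1` comes from compound 1 by a single change, sec-butoxy in place of 3-methylpiperidin-1-yl on an aromatic carbon. With no value for compound 1, the size of this step in this assay cannot be read directly, so the expectation leans on the nearest measured compound without the 3-methylpiperidin-1-yl, compound 3 at < 25 ug/mL. A low reading is therefore expected, possibly only a limit. Compound 4 is estimated at 18 ug/mL, with an expected range of 6 ug/mL to 50 ug/mL.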

Compound 4, solubility: 50 ug/mL
Estimate against measurement, compound 4: 2.8-fold (0.44 log units) below, within the range that was stated.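

No new step can be read between compound 1 and compound 4, since compound 1 has no result in this assay. The compounds shown leave open what sec-butoxy in place of 3-methylpiperidin-1-yl does on this read-out, and nothing shown accounts for the result of compound 4.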